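Ring size on the carbamate nitrogen and receptor binding

The source may hold more compounds than are shown below. What is called first, only, known or untested is meant among the compounds shown, and "the series" means these compounds.

Measured compounds:
compound 1 `COc1ccc(CC(=O)O)cc1-c1ccc(C(F)(F)F)cc1CN(C(=O)OCc1ccccc1)C1CCCC1`: 53 nM
compound 2 `COc1ccc(CC(=O)O)cc1-c1ccc(C(F)(F)F)cc1CN(C(=O)OCc1ccccc1)C1CC1`: 18 nM

In an in vitro assay on 293T cells for displacement of a labelled ligand from prostaglandin D2 receptor 2 (Homo sapiens), read by scintillation counting, in the presence of a further agent that is not named here (on this read-out higher numbers stand for weaker inhibition and lower numbers for stronger inhibition), compound 2 gives the lower of the two numbers, and compound 1 gives the higher. The step of a 2.9-fold lower number from compound 1 to compound 2 (0.47 log units; beyond the scatter) is the only one measured, and it shows that shrinking the ring on this nitrogen from cyclopentyl to cyclopropyl went along with a modest gain. Compound 3 `COc1ccc(CC(=O)O)cc1-c1ccc(C(F)(F)F)cc1CN(C(=O)OCc1ccccc1)C1CCC1` carries the change (cyclobutyl in place of cyclopropyl on an amide-type nitrogen), so its ring has one member more than that of compound 2 and one fewer than that of compound 1. Since the measured step runs from the larger ring to the smaller one with a modest gain, the reverse move to a ring of intermediate count is expected to give a small loss at most, likely close to the scatter. Compound 3 is therefore expected to give 30 nM, within 12 nM to 75 nM, a step of a 1.7-fold higher number from compound 2 to compound 3 (0.22 log units; within the scatter).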

Compound 3, half-maximal inhibitory concentration: 19 nM
Compound 3: middle estimate off by 1.6-fold (0.20 log units), on the high side, and the stated range covers the measured number.
By their numbers in this assay, from the lowest: compounds 2 and 3 (each within the scatter of the next); then compound 1.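

In this assay the cyclobutyl and cyclopropyl groups on this amide-type nitrogen cannot be told apart, with a 1.1-fold higher number from compound 2 to compound 3 (0.02 log units; within the scatter) and so no measurable penalty for the extra ring carbon. The cyclopentyl ring is the one that stands apart, with a 2.8-fold lower number from compound 1 to compound 3 (0.45 log units; beyond the scatter) and a similar gap to compound 2, so among these three compounds the numbers do not shift evenly with ring size: the only difference beyond the scatter lies between the five-membered ring and the two smaller rings. Nothing available explains why the numbers divide in this way.

Going by these compounds, what a cyclohexyl ring on the same nitrogen would give remains open, and so does whether the ring itself matters. An open-chain group such as isopropyl, or a ring containing oxygen such as oxetanyl, could speak to that second question.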